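The source may report more compounds than this note shows. Statements on the series, on what has been measured and on what is new or still open speak of the compounds shown alone.

Measured so far:
compound 1 `CN1C(=O)C2=C(C1=O)N(CC(=O)Nc1ccc(-c3cccnc3)nn1)CCC2`: 95%
compound 2 `Cc1ccc(-c2ccc(NC(=O)CN3CCCC4=C3C(=O)N(C3CC3)C4=O)nn2)cn1`: 98.1%

In an ADME assay on a cell-free system (plasma) for protein binding, compound 2 at 98.1% has the lowest unbound fraction of the two measured compounds, and the gap to compound 1 lies beyond the scatter. Compound 3 `Cc1ccc(-c2ccc(NC(=O)CN3CCCC4=C3C(=O)N(C)C4=O)nn2)cn1` differs from compound 2 in one place: methyl in place of cyclopropyl on an amide-type nitrogen in a ring. Within the data shown here, no measured step isolates this change. Compound 1 also carries methyl on such a nitrogen and gives 95% in this assay but differs from compound 2 elsewhere as well, so it is only a loose guide. The expected change is a small move towards more free compound, about the size of the scatter (a 1.7-fold higher unbound fraction from compound 2 to compound 3 (0.23 log units; within the scatter)). For compound 3 the estimate is 96.8% in this assay, with an expected range of 94.5% to 98.2% for repeat measurements.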

Compound 3, plasma protein binding: 96.9%
The estimate for compound 3 lay 1.0-fold (0.01 log units) (unbound fraction) above the measured number, within the range that was stated.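

In this assay, methyl in place of cyclopropyl on an amide-type nitrogen in a ring now has a measured step of its own: a 1.6-fold higher unbound fraction from compound 2 to compound 3 (0.21 log units; within the scatter), so at this position the two groups cannot be told apart in this read-out. Methyl in place of hydrogen on an aromatic carbon also gains a step, a 1.6-fold lower unbound fraction from compound 1 to compound 3 (0.21 log units; within the scatter), so this second position likewise shows no change beyond the scatter. Nothing on hand gives a reason for either step.

At the amide-type nitrogen in a ring, only methyl and cyclopropyl are shown, so the outcome with a carboxylic acid, an amine or a longer chain there remains open. On the aromatic carbon, only hydrogen and methyl are compared, leaving groups such as methoxy or fluorine unaddressed.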